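A few compounds are considered here, and "the series" means these few. Any claim that something is new, unique, unknown or untested is made for them only; others in the source may bear on it.

Measured so far in a functional assay on HOS-TE85 cells (Homo sapiens) for inhibition, read by CCK-8 assay, with a stated time of 72 h; a lower number here means a stronger inhibitor, a higher number a weaker inhibitor:
compound 1 `O=C(NCCCCn1cccn1)c1cccc(C2SCC(=O)N2c2cc(Br)ccn2)c1` gives 105 nM
compound 2 `Cc1ccnc(N2C(=O)CSC2c2cccc(C(=O)NCCCCn3cccn3)c2)c1` gives 19.6 nM
compound 3 `COc1cc(F)ccc1N1C(=O)CSC1c1cccc(C(=O)NCCCCc2ccccc2)c1` gives 71.1 nM

Compound 3 stands second highest of the three numbers in this assay. Its nearest neighbour is compound 1, whose number is higher by a margin within the scatter, so the two cannot be ordered; compound 2 lies furthest away, with a lower number beyond the scatter.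

The next compound, compound 4 `COc1c(F)cccc1N1C(=O)CSC1c1cccc(C(=O)NCCCCc2ccccc2)c1`, differs from compound 3 by 3-fluoro-2-methoxyphenyl in place of 4-fluoro-2-methoxyphenyl on an amide-type nitrogen in a ring. The atoms are the same; only the fluorine changes position within the group on the amide-type nitrogen in a ring.

Among the compounds with values here, only one measured step exists, a 5.4-fold lower number from compound 1 to compound 2 (0.73 log units; beyond the scatter). It also alters a group on the amide-type nitrogen in a ring, but it exchanges one substituent for another rather than moving a fluorine from one carbon to another, so it does not speak directly to the change in hand. Within the data shown here, no measured pair shows a positional shift of a fluorine.

Among the measured compounds shown here, with no direct precedent, the expectation for compound 4 is a step of a 1.0-fold lower number from compound 3 to compound 4 (0.01 log units; within the scatter) in this assay, meaning no change beyond the scatter. Compound 4 is estimated at 70 nM, expected within 25 nM to 200 nM.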

Compound 4, half-maximal inhibitory concentration: 26.2 nM
Compound 4: middle estimate off by 2.7-fold (0.43 log units), on the high side, and the stated range covers the measured number.
By their numbers in this assay, from the lowest: compounds 2 and 4 (each within the scatter of the next); then compounds 3 and 1 (each within the scatter of the next).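

In this assay, 3-fluoro-2-methoxyphenyl in place of 4-fluoro-2-methoxyphenyl on the amide-type nitrogen in a ring gives a 2.7-fold lower number from compound 3 to compound 4 (0.43 log units; beyond the scatter), so at this place a change in the arrangement of the same atoms is enough to move the number beyond the scatter. The earlier step at this place exchanged bromo for methyl and so changed the substituent itself; the new step shows that the position of a fluorine also registers in this assay, at least for this one pair on the core of compound 3. No measurement on hand accounts for the step, so the result stands as an observation on a single pair.

From the compounds shown here alone, whether the step carries over to compounds bearing the amide side chain of compound 1 and compound 2 remains open, since this fluorine shift is read on only one side chain. Also open, going by these compounds, is whether chlorine or a nitrile in the place of the fluorine would follow the same positional trend, or whether the step is particular to fluorine.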